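The source may report more compounds than this note shows. Statements on the series, on what has been measured and on what is new or still open speak of the compounds shown alone.

Compound 1 `COc1ccc(/C=C(\C#N)C(=O)N/N=C(\C)c2c(O)c3ccc(O)cc3oc2=O)cc1OC` gives 45300 nM in a functional assay on NRK-49F cells (Rattus norvegicus) for cytotoxicity, read by MTT assay, with a stated time of 24 h (a lower number here means a stronger inhibitor, a higher number a weaker inhibitor), and so sits level with compound 2 `C/C(=N\NC(=O)/C(C#N)=C/c1cccc([N+](=O)[O-])c1)c1c(O)c2ccc(O)cc2oc1=O` at 46500 nM and compound 3 `C/C(=N\NC(=O)/C(C#N)=C/c1ccc([N+](=O)[O-])cc1)c1c(O)c2ccc(O)cc2oc1=O` at 43200 nM on the same scale, with all three inside the scatter of one another. Compound 4 `C/C(=N\NC(=O)/C(C#N)=C/c1ccccc1Cl)c1c(O)c2ccc(O)cc2oc1=O` has not yet been measured. Its change from compound 1 is 2-chlorophenyl in place of 3,4-dimethoxyphenyl on a double-bonded chain carbon bound to a double-bonded chain carbon and the rest of the structure stays the same. Swaps at this same place have so far moved the number very little: the measured ones are a 1.0-fold higher number from compound 1 to compound 2 (0.01 log units; within the scatter) and a 1.0-fold lower number from compound 1 to compound 3 (0.02 log units; within the scatter) and a 1.1-fold lower number from compound 2 to compound 3 (0.03 log units; within the scatter) with each of them within the scatter. Going by the values given here, no chlorine-bearing compound has been measured, so this guide is only a borrowed one. On the strength of those small steps, a 1.0-fold lower number from compound 1 to compound 4 (0.01 log units; within the scatter) is the expected step, which means no change beyond the scatter in either direction. In this assay the estimated value for compound 4 is 44000 nM with an expected range from 24000 nM to 80000 nM for repeat measurements.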

Compound 4, half-maximal inhibitory concentration: 55900 nM
For compound 4 the middle estimate is 1.3-fold (0.10 log units) below the measured one, and the stated range covers the measured number.
By their numbers in this assay, from the lowest: compounds 3, 1, 2 and 4 (each within the scatter of the next).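

In this assay, this position on a double-bonded chain carbon bound to a double-bonded chain carbon now also accepts a chlorine-bearing ring with no real shift: 2-chlorophenyl gives a 1.2-fold higher number from compound 1 to compound 4 (0.09 log units; within the scatter), a 1.2-fold higher number from compound 2 to compound 4 (0.08 log units; within the scatter) and a 1.3-fold higher number from compound 3 to compound 4 (0.11 log units; within the scatter). The number therefore stays level even though the entering 2-chlorophenyl has 7 heavy atoms and 0 hydrogen-bond acceptors, against 10 heavy atoms and 2 hydrogen-bond acceptors in the departing 3,4-dimethoxyphenyl. Nothing measured explains why these swaps leave the number unchanged.

The compounds shown leave open whether any group at this position can move the number beyond the scatter, such as an amine or a carboxylic acid on the ring, or a longer chain in its place. They also cannot say whether changes elsewhere on the shared core would matter more.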